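The source may hold more compounds than are shown below. What is called first, only, known or untested is meant among the compounds shown, and "the series" means these compounds.

Measured in a functional assay on HCT-116 cells (Homo sapiens) for cytotoxicity, read by sulforhodamine B assay, with a stated time of 48 h (a higher number here means a weaker inhibitor of growth, a lower number a stronger inhibitor of growth), so far:
compound 1 `COc1cc(C(=O)c2ccc(OC)c(O)c2OC)cc(OC)c1O` gives 1410 nM
compound 2 `COc1cc(C(=O)c2ccc3c(c2)oc(=O)n3S(C)(=O)=O)cc(OC)c1OC` gives 2310 nM

Compound 1 and compound 2 sit within the usual scatter of each other, so neither stands apart on these numbers. Compound 3 `COc1ccc(C(=O)c2cc(OC)c(OC)c(OC)c2)c(OC)c1O` differs from compound 1 in one place (methyl in place of hydrogen on an oxygen on an aromatic ring): methyl in place of hydrogen on an oxygen on an aromatic ring, or hydroxy to methoxy. Within the data shown here, no measured pair shows this change alone, so the data give no direct guide. The expected step (a 3.5-fold lower number from compound 1 to compound 3 (0.55 log units; beyond the scatter)) is a moderate one toward a lower number in this assay and is uncertain, and no change beyond the scatter remains possible. Compound 3 is estimated at 400 nM (range 60 nM to 2000 nM).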

Compound 3, concentration for 50% growth inhibition: 32 nM
The estimate for compound 3 lay 13-fold (1.10 log units) above the measured number; the measured number lies below the stated range.
By their numbers in this assay, from the lowest: compound 3; then compounds 1 and 2 (each within the scatter of the next).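

In this assay the change of hydroxy to methoxy at this one oxygen gives a 44-fold lower number from compound 1 to compound 3 (1.64 log units; beyond the scatter) and nothing else differs between the two structures. Among these compounds, this is the first sign that growth inhibition here depends strongly on a single group, since compound 1 and compound 2 could not be told apart and differ in more than one place. Nothing measured here explains the size of this step. From the compounds shown here alone, whether a longer chain such as ethyl on this oxygen would also give a low number remains open. So does the effect of an amine in place of the hydroxy that compound 3 still carries.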